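A few compounds are considered here, and "the series" means these few. Any claim that something is new, unique, unknown or untested is made for them only; others in the source may bear on it.

Compound 1 `O=C(Nc1nc(-c2ccc(Cl)cc2)cs1)c1cc([N+](=O)[O-])ccc1Cl` carries the shared core of this small set. Going by the values given here, in an ADME assay on HEK293 cells (Homo sapiens) for cytotoxicity, with a stated time of 72 h (a higher number here means that more compound is needed for the effect, a lower number that less compound is needed), compound 1 gives 15000 nM, the only number reported among the three measured compounds. Compound 2 `O=C(Nc1cc(-c2nc3ccccc3o2)ccc1F)c1cc([N+](=O)[O-])ccc1Cl` reaches only a limit of this assay, > 25000 nM. Compound 3 `COc1cc(Cl)c(C(=O)Nc2cccc(-c3nc4ccccc4s3)c2)cc1[N+](=O)[O-]` likewise reaches only a limit of this assay, > 25000 nM. Among the compounds with values here, compound 1 therefore stands as the single measured number, while the other two sit at the limit of > 25000 nM in this assay, at which 2 of the 3 values shown sit. Compound 4 `O=C(Nc1nc(-c2ccc(F)c(F)c2)cs1)c1cc([N+](=O)[O-])ccc1Cl` differs from compound 1 by 3,4-difluorophenyl in place of 4-chlorophenyl on an aromatic carbon. Within the data shown here, no step between measured compounds is available to guide the size of this change, so the expected step of a 1.2-fold higher number from compound 1 to compound 4 (0.08 log units; within the scatter) is small, within the scatter or slightly upward. Compound 4 is expected to give about 18000 nM in this assay, somewhere between 8000 nM and 40000 nM.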

Compound 4, half-maximal effective concentration: 8300 nM
Beside the measured number, compound 4's estimate is 2.2-fold (0.34 log units) above it; the range from low to high includes it.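

Going by these compounds alone, at this aromatic carbon, next to the ring nitrogen, 3,4-difluorophenyl in place of 4-chlorophenyl gives the only step that can be read in this assay, namely a 1.8-fold lower number from compound 1 to compound 4 (0.26 log units; within the scatter), so this exchange of one halogenated phenyl for another does not move the number beyond the scatter. Nothing given here accounts for the size of this step. The compounds shown leave open whether an amine, a carboxylic acid or a longer chain at this position would shift the number in this assay beyond the scatter.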